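Methyl for Chloro in a Series of Imidazole Ethers

The source may report more compounds than this note shows. Statements on the series, on what has been measured and on what is new or still open speak of the compounds shown alone.

Three compounds have so far been measured in an ADME assay on K562 cells (Homo sapiens) for cytotoxicity, read by MTT assay, with a stated time of 24 h; a higher number here means that more compound is tolerated, a lower number that less compound is tolerated:

Compound 1, `Clc1ccc(OC(CCn2ccnc2)c2ccccc2)cc1`, gives 256000 nM.
Compound 2, `Cc1ccc(OC(CCn2ccnc2)c2ccccc2)cc1`, gives 95900 nM.
Compound 3, `Cc1ccc(C(CCn2ccnc2)Oc2ccc(Cl)cc2)cc1`, gives 171000 nM.

Compound 2 differs from compound 1 by methyl in place of chloro on an aromatic carbon, and this gave a 2.7-fold lower number from compound 1 to compound 2 (0.43 log units; beyond the scatter). Compound 3 differs from compound 1 by methyl in place of hydrogen on an aromatic carbon, giving a 1.5-fold lower number from compound 1 to compound 3 (0.18 log units; within the scatter).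

Compound 4, `Cc1ccc(OC(CCn2ccnc2)c2ccc(C)cc2)cc1`, has not yet been measured. It differs from compound 3 by methyl in place of chloro on an aromatic carbon. Going by the values given here, this is the same change as the one from compound 1 to compound 2, set on the core of compound 3 rather than the core of compound 1. Among the compounds with values here, since it is the second time the change appears, the step from compound 1 to compound 2 is the only guide, and compound 4 is expected to lie a step of about a 2.5-fold lower number from compound 3 to compound 4 (0.40 log units; beyond the scatter) in this assay, resting on a 2.7-fold lower number from compound 1 to compound 2 (0.43 log units; beyond the scatter). Compound 4 is therefore estimated at 68000 nM, in a range from 30000 nM to 150000 nM.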

Compound 4, half-maximal cytotoxic concentration: 191000 nM
For compound 4 the middle estimate is 2.8-fold (0.45 log units) below the measured one; the whole stated range lies below it.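

In this assay, the exchange of chloro for methyl shows a 1.1-fold higher number from compound 3 to compound 4 (0.05 log units; within the scatter), and the added methyl shows a 2.0-fold higher number from compound 2 to compound 4 (0.30 log units; within the scatter), so neither step on the second core lies beyond the scatter. The exchange of chloro for methyl therefore does not carry its size from one core to the other in this series: the same change on two cores in this assay, a 2.7-fold lower number (0.43 log units; beyond the scatter) from compound 1 to compound 2 and a 1.1-fold higher number (0.05 log units; within the scatter) from compound 3 to compound 4, 3.0-fold (0.47 log units) apart, beyond the scatter of two such steps. This rests on a single pair of cores and does not show why the steps differ or how any further core would respond, and the added methyl gives the same picture: the same change on two cores in this assay, a 1.5-fold lower number (0.18 log units; within the scatter) from compound 1 to compound 3 and a 2.0-fold higher number (0.30 log units; within the scatter) from compound 2 to compound 4, 3.0-fold (0.47 log units) apart, beyond the scatter of two such steps.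

The compounds shown leave open whether a fluoro or a methoxy group in the place of the chloro or methyl would follow either step. They also leave open how a longer chain carrying the imidazole would change the number in this assay.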